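This account rests on a few compounds, and the source may have more. Where it says the series, first, only, none or still open, it means among the compounds named here.

Of the compounds shown here, three built on one shared core have been measured in a functional assay on A549 cells (Homo sapiens) for inhibition, read by MTT assay, with a stated time of 96 h; on this read-out lower numbers stand for stronger inhibition of growth and higher numbers for weaker inhibition of growth. There, compound 1 `O=C(NCCCCCCSSCCCCCCNC(=O)c1cc(-c2ccncc2)n[nH]1)c1cc(-c2ccncc2)n[nH]1` gives 6070 nM, compound 2 `C=CCOC(=O)SCCCCCCNC(=O)c1cc(-c2ccncc2)n[nH]1` gives 15200 nM and compound 3 `CC(=O)SCCCCCCNC(=O)c1cc(-c2ccncc2)n[nH]1` gives 18000 nM. Compound 2 stands level with compound 3 within the scatter, and its number is higher than that of compound 1 by a gap beyond the scatter. Compound 4 `CSCCCCCCNC(=O)c1cc(-c2ccncc2)n[nH]1` departs from compound 2 with methyl in place of allyloxycarbonyl on a sulfur. Among the compounds with values here, one measured step bears on this change: a 1.2-fold higher number from compound 2 to compound 3 (0.07 log units; within the scatter). That step also replaces the allyloxy part with methyl but keeps the carbonyl on the sulfur, so it is only a partial guide. Within the data shown here, no measured compound carries methyl directly on the sulfur. On that limited evidence, no change beyond the scatter is expected in this assay, with at most a slight lean towards a higher number. The expected step is a 1.3-fold higher number from compound 2 to compound 4 (0.12 log units; within the scatter). For compound 4, the estimated value is 20000 nM, within an expected range of 9000 nM to 45000 nM.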

Compound 4, concentration for 50% growth inhibition: > 50000 nM
Compound 4 gave a limit, no number (the forecaster's own chance of this, stated with the estimate: 10%); at least 2.5-fold (0.39 log units) between middle value and limit.
By their numbers in this assay, from the lowest: compound 1; then compounds 2 and 3 (each within the scatter of the next). At a limit, above all of these: compound 4.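

In this assay, compound 4 gives a limit and not a number: the limit of > 50000 nM in this assay, at which 1 of the 4 values shown sits. Loss of the carbonyl from the sulfur therefore carries the read-out beyond the scatter, with an at least 3.2-fold higher number from compound 2 to compound 4 (0.51 log units; beyond the scatter) and an at least 2.7-fold higher number from compound 3 to compound 4 (0.44 log units; beyond the scatter), and both steps are bounds whose full size remains unknown. The earlier compounds did not show this, since the one step that keeps the carbonyl on the sulfur, a 1.2-fold higher number from compound 2 to compound 3 (0.07 log units; within the scatter), stays within the scatter, so what sits on that carbonyl has shown little weight so far, while the carbonyl's removal has a clear one.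

The compounds shown leave open whether the free thiol would behave like the carbonyl-bearing compounds or like compound 4. They also leave open whether an ethyl or benzyl group on the sulfur would stay at the same limit.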